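The source may hold more compounds than are shown below. What is called first, only, known or untested is meant among the compounds shown, and "the series" means these compounds.

Compounds measured so far:
compound 1 `C[C@]1(CO)OC[C@@H](n2ccc(N)nc2=O)O1` — 45000 nM
compound 2 `CC1(CO)OCC(n2ccc(N)nc2=O)O1` — 50000 nM
compound 3 `C[C@]1(CO)OCC(n2ccc(N)nc2=O)O1` — a limit, > 100000 nM

In a functional assay on L1210 cells (Mus musculus) for inhibition (on this read-out higher numbers stand for weaker inhibition and lower numbers for stronger inhibition), compound 1 gives 45000 nM and compound 2 gives 50000 nM. For compound 3 this assay returns only a limit, > 100000 nM, so compound 3 stands on a floor rather than on a number, see (the limit of > 100000 nM in this assay, at which 1 of the 3 values shown sits). Compound 4 is `CC1(CO)OC[C@@H](n2ccc(N)nc2=O)O1`. Its difference from compound 3: the two compounds have the same atoms and bonds; at least one stereo element is drawn with a configuration in one of them and without one in the other: 2 of 2 stereo elements differ; a stereocentre at a saturated ring carbon is drawn S in compound 3 and without a configuration in compound 4; a stereocentre at a saturated ring carbon is drawn without a configuration in compound 3 and S in compound 4. Among the compounds with values here, compound 4 thus carries the configuration that compound 3 leaves undefined and leaves undefined the one compound 3 carries. Within the data shown here, the steps that bear on this change are a 1.1-fold higher number from compound 1 to compound 2 (0.05 log units; within the scatter), an at least 2.2-fold higher number from compound 1 to compound 3 (0.34 log units; beyond the scatter) and an at least 2.0-fold higher number from compound 2 to compound 3 (0.30 log units; that floor lies within the scatter), together with the fact that one of compounds 1 and 2 is drawn with a defined configuration and the other without, at the place where they differ, the fact that one of compounds 1 and 3 is drawn with a defined configuration and the other without, at the place where they differ and (the fact that one of compounds 2 and 3 is drawn with a defined configuration and the other without, at the place where they differ). Removing a defined configuration from compound 1 to compound 2 left the number unchanged within the scatter, whereas compound 3 sits only at a floor. Compound 4 is therefore expected to return a number close to compounds 1 and 2, and the step of an at least 1.6-fold lower number from compound 3 to compound 4 (0.22 log units; that floor lies within the scatter) is expected to be downward or none. The estimate for compound 4 is 60000 nM, with a range from 25000 nM to 150000 nM.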

Compound 4, half-maximal inhibitory concentration: > 100000 nM
Compound 4 was reported as a limit (the forecaster's own chance of this, stated with the estimate: 30%); middle value at least 1.6-fold (0.22 log units) away from the limit.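

In this assay compound 4 gives > 100000 nM, which is a limit. Against the two compounds that return numbers, this gives an at least 2.2-fold higher number from compound 1 to compound 4 (0.34 log units; beyond the scatter) and an at least 2.0-fold higher number from compound 2 to compound 4 (0.30 log units; that floor lies within the scatter). Compound 3 and compound 4, each with only one of the two stereocentres drawn with a configuration, both end at the limit, whereas compound 1, with both drawn, and compound 2, with neither drawn, return numbers; the step between compound 3 and compound 4 cannot be read.

From the compounds shown here alone, whether compound 3 and compound 4 differ from each other stays open, since neither has a number in this assay. The compounds shown also say nothing about an amine or a carboxylic acid in place of the hydroxyl group.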